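Replacing the naphthalen-2-yl group of compound 3

The compounds below may be only part of what the source reports. "The series", "measured", "known", "first", "only" and "open" are said of these compounds alone.

In a functional assay on MCF7 cells (Homo sapiens) for inhibition, read by MTT assay, with a stated time of 24 h (a lower number here means a stronger inhibitor, a higher number a weaker inhibitor), compound 1 `O=C1CSC(c2c[nH]nc2-c2ccc(F)cc2)N1n1c(S)nnc1COc1ccccc1` gives 30 ug/mL and compound 2 `COc1ccc(-c2n[nH]cc2C2SCC(=O)N2n2c(S)nnc2COc2ccccc2C)cc1` gives 29 ug/mL. Compound 3 `O=C1CSC(c2c[nH]nc2-c2ccc(F)cc2)N1n1c(S)nnc1COc1ccc2ccccc2c1` gives only > 100 ug/mL, which is a limit of the assay and not a number. Compound 4 `Cc1ccccc1OCc1nnc(S)n1N1C(=O)CSC1c1c[nH]nc1-c1ccc(F)cc1` carries 2-methylphenyl in place of naphthalen-2-yl on an oxygen on a saturated carbon. Among the compounds with values here, the one measured step that bears on this is an at least 3.3-fold higher number from compound 1 to compound 3 (0.52 log units; beyond the scatter), which put naphthalen-2-yl in place of phenyl and lies beyond the scatter. Compound 2 also carries 2-methylphenyl, on a different core, and its 29 ug/mL points the same way. A step of similar size toward a stronger inhibitor is therefore expected, estimated as an at least 2.8-fold lower number from compound 3 to compound 4 (0.45 log units; beyond the scatter). For compound 4 the expected value is 35 ug/mL, with an estimated range of 16 ug/mL to 80 ug/mL.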

Compound 4, half-maximal inhibitory concentration: > 100 ug/mL
Compound 4: only a limit was reported; the forecaster's own chance of this, stated with the estimate: 15%; middle value at least 2.8-fold (0.45 log units) away from the limit.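

Methyl in place of hydrogen on an aromatic carbon gives an at least 3.3-fold higher number from compound 1 to compound 4 (0.52 log units; beyond the scatter), so a single added methyl on the phenyl group is enough to lose the measurable activity of compound 1. Fluoro in place of methoxy on an aromatic carbon gives an at least 3.4-fold higher number from compound 2 to compound 4 (0.53 log units; beyond the scatter), so the effect of 2-methylphenyl at this position depends on a group elsewhere in the molecule. The step from compound 3 to compound 4 cannot be read, since both values are limits and not numbers: the limit of > 100 ug/mL in this assay, at which 2 of the 4 values shown sit.

Still open, as far as these compounds go, is whether an amine or a carboxylic acid in place of that methyl would keep the activity of compound 1.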